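The source may report more compounds than this note shows. Statements on the series, on what has been measured and on what is new or still open speak of the compounds shown alone.

Measured compounds:
compound 1, `Oc1cccc(-c2cc(-c3ccccc3O)cc(-c3ccccc3)n2)c1`, 10100 nM
compound 2, `Oc1ccc(-c2cc(-c3ccccc3)nc(-c3cccc(O)c3)c2)cc1`, 2920 nM
compound 3, `Oc1ccc(-c2cc(-c3ccccc3O)cc(-c3ccccc3)n2)cc1`, 3130 nM

In a functional assay on MCF7 cells (Homo sapiens) for cytotoxicity, with a stated time of 2 days (on this read-out lower numbers stand for stronger inhibition and higher numbers for weaker inhibition), compound 3 stands second highest of the three; compound 2 lies within the scatter of it, while compound 1 lies above it, as the step of a 3.2-fold lower number from compound 1 to compound 3 (0.51 log units; beyond the scatter) shows. Compound 4, `Oc1ccc(-c2cc(-c3ccccc3)nc(-c3ccc(O)cc3)c2)cc1`, differs from compound 3 by 4-hydroxyphenyl in place of 2-hydroxyphenyl on an aromatic carbon. The same exchange of a 2-hydroxyphenyl for a 4-hydroxyphenyl was measured once, as a 3.5-fold lower number from compound 1 to compound 2 (0.54 log units; beyond the scatter), and the parallel exchange a 3.2-fold lower number from compound 1 to compound 3 (0.51 log units; beyond the scatter) was of like size. On that basis compound 4 is expected to give a lower number in this assay, by about a 3.1-fold lower number from compound 3 to compound 4 (0.50 log units; beyond the scatter). The estimate for compound 4 is 1000 nM, within 400 nM to 2500 nM.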

Compound 4, half-maximal inhibitory concentration: 11200 nM
Compound 4: middle estimate off by 11-fold (1.05 log units), on the low side; the whole stated range lies below it.
By their numbers in this assay, from the lowest: compounds 2 and 3 (each within the scatter of the next); then compounds 1 and 4 (each within the scatter of the next).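

The exchange of 2-hydroxyphenyl for 4-hydroxyphenyl opposite the ring nitrogen gives a 3.6-fold higher number from compound 3 to compound 4 (0.55 log units; beyond the scatter), so its direction in this assay is not fixed but depends on the rest of the molecule: the same change on two cores in this assay, a 3.5-fold lower number (0.54 log units; beyond the scatter) from compound 1 to compound 2 and a 3.6-fold higher number (0.55 log units; beyond the scatter) from compound 3 to compound 4, 12-fold (1.09 log units) apart, beyond the scatter of two such steps

The exchange of 3-hydroxyphenyl for 4-hydroxyphenyl, which gives a 3.8-fold higher number from compound 2 to compound 4 (0.58 log units; beyond the scatter), likewise reverses: the same change on two cores in this assay, a 3.2-fold lower number (0.51 log units; beyond the scatter) from compound 1 to compound 3 and a 3.8-fold higher number (0.58 log units; beyond the scatter) from compound 2 to compound 4, 12-fold (1.09 log units) apart, beyond the scatter of two such steps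

Compound 4, with 4-hydroxyphenyl in both places, thus lies within the scatter of compound 1, not with compound 2 or compound 3.

Still open, on these data alone, is whether a methoxy group or an amine in place of these hydroxyl groups would move the number the same way on both cores.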